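This account rests on a few compounds, and the source may have more. Where it says the series, first, only, none or still open, it means among the compounds named here.

In a functional assay on HepG2 cells (Homo sapiens) for cytotoxicity, read by MTT assay, with a stated time of 48 h (on this read-out higher numbers stand for weaker inhibition and lower numbers for stronger inhibition), the measured compounds give these values:

- compound 1 `Cc1ccc(C(=O)N2N=C(c3cc4ccccc4oc3=O)CC2c2ccccc2)cc1` gives 52300 nM
- compound 2 `CCCNCC(=O)N1N=C(c2cc3ccccc3oc2=O)CC1c1ccccc1` gives 10800 nM
- compound 3 `O=C(CN1CCCC1)N1N=C(c2cc3ccccc3oc2=O)CC1c1ccccc1` gives 44300 nM

Compound 3 cannot be told apart from compound 1, as shown by a 1.2-fold lower number from compound 1 to compound 3 (0.07 log units; within the scatter). It clearly differs from compound 2, as shown by a 4.1-fold higher number from compound 2 to compound 3 (0.61 log units; beyond the scatter).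

The next compound, compound 4 `CC1CCCN(CC(=O)N2N=C(c3cc4ccccc4oc3=O)CC2c2ccccc2)C1`, changes only the ring on the side chain: 3-methylpiperidin-1-yl in place of pyrrolidin-1-yl on a saturated chain carbon bound to a carbonyl carbon. The closest evidence is a 4.1-fold higher number from compound 2 to compound 3 (0.61 log units; beyond the scatter), a modest step made at this same place. The swap of the 4-methylphenyl group, seen in a 4.8-fold lower number from compound 1 to compound 2 (0.69 log units; beyond the scatter) and a 1.2-fold lower number from compound 1 to compound 3 (0.07 log units; within the scatter), gave a modest step in one case and none beyond the scatter in the other. Among the compounds with values here, no measured compound tests a six-membered ring or a methyl group at this place, so the direction remains open and no step beyond the scatter is expected.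

In this assay the expected change is a 1.3-fold lower number from compound 3 to compound 4 (0.10 log units; within the scatter). The estimate for compound 4 is 35000 nM, with an expected range of 13000 nM to 80000 nM.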

Compound 4, half-maximal inhibitory concentration: "not active" (no number reported)
Nothing numeric was reported for compound 4; the estimate stays without a comparison.
By their numbers in this assay, from the lowest: compound 2; then compounds 3 and 1 (each within the scatter of the next).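

In this assay, within the data shown here, compound 4 is reported only as "not active", without a number, so no step from compound 3 to compound 4 can be read. The compounds shown leave open how a six-membered ring or a methyl group at this place changes the number. Nothing measured here explains this result.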